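The source may hold more compounds than are shown below. What is called first, only, known or untested is meant among the compounds shown, and "the series" means these compounds.

Measured so far in an assay on HEK293 cells for binding affinity to 5-hydroxytryptamine receptor 7 (Homo sapiens), read by radioligand binding, tested at 1 uM; on this read-out higher numbers stand for more inhibition at the one concentration tested (going by the name of the read-out) and lower numbers for less inhibition:

Compound 1, `CN1CCCN(CCn2ccc3ccc(OCc4ccccc4)cc32)CC1`: 28%
Compound 2, `C#Cc1ccc2ccn(CCN3CCCN(C)CC3)c2c1`: 79%

Among the measured compounds shown here, compound 2 stands highest of the two numbers; its only neighbour on this read-out is compound 1, and the step of a number 51 percentage points higher from compound 1 to compound 2 (beyond the scatter), ethynyl in place of benzyloxy on an aromatic carbon, is the one measured step and lies beyond the scatter.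

Compound 3, `CN1CCCN(CCn2ccc3ccc(-c4cccnc4)cc32)CC1`, is not yet measured. It differs from compound 2 as follows: pyridin-3-yl in place of ethynyl on an aromatic carbon.

The step from compound 1 to compound 2 is the only one that bears on this change, and only indirectly: it shows that a larger substituent at this aromatic carbon, benzyloxy, went with a much lower number than ethynyl. Pyridin-3-yl is again larger than ethynyl but smaller than benzyloxy and carries one hydrogen-bond acceptor, so a downward step in this assay is expected, of a size below that of the measured step, though the data do not fix it; the expected step is a number 24 percentage points lower from compound 2 to compound 3 (beyond the scatter).

For compound 3 the estimate in this assay is 55%, with a range from 30% to 80%.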

Compound 3, a percentage reported as inhibition, at one concentration (the size of the read-out at that concentration, not a potency): 35%
Estimate against measurement, compound 3: 20 percentage points above; the range from low to high includes it.
By their numbers in this assay, from the lowest: compounds 1 and 3 (each within the scatter of the next); then compound 2.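

In this assay pyridin-3-yl on this aromatic carbon gives a number 44 percentage points lower from compound 2 to compound 3 (beyond the scatter) and so shows that the low number of compound 1 is not tied to benzyloxy alone. A second, quite different replacement of ethynyl also ends far down, and among the three groups shown only ethynyl goes with a high number. Pyridin-3-yl and benzyloxy are not told apart here, with a number 7 percentage points higher from compound 1 to compound 3 (within the scatter) as their step, so an aromatic ring carrying one nitrogen in this place brings no measurable recovery over benzyloxy. Nothing available explains the fall from ethynyl to pyridin-3-yl.

Still open, going by these compounds, is whether the high number of compound 2 belongs to the triple bond itself or simply to a group of few atoms, a question that a nitrile or a methyl on this carbon would address. Phenyl in place of pyridin-3-yl would show whether the ring nitrogen has any part in the low number, while the rest of the shared core stays the same throughout and so remains untested.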